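A few compounds are considered here, and "the series" means these few. Any claim that something is new, unique, unknown or untested is made for them only; others in the source may bear on it.

Three compounds that share a core bearing a hydroxymethyl group, either free or masked by a large silicon-based group, have been tested in a functional assay on aorta (Rattus norvegicus); on this read-out higher numbers stand for weaker inhibition and lower numbers for stronger inhibition. Compound 3 `Cn1nc(CO[Si](c2ccccc2)(c2ccccc2)C(C)(C)C)ccc1=O` carries a methyl on an aromatic nitrogen together with the large group; in this assay compound 3 gives 58400 nM. Compound 1 `CC(C)(C)[Si](OCc1ccc(=O)[nH]n1)(c1ccccc1)c1ccccc1` is its counterpart with hydrogen in place of methyl on an aromatic nitrogen; in this assay compound 1 gives 62600 nM. That change, (hydrogen in place of methyl on an aromatic nitrogen), made a 1.1-fold higher number from compound 3 to compound 1 (0.03 log units; within the scatter). Compound 2 `Cn1nc(CO)ccc1=O` keeps the methyl but carries the free hydroxymethyl group. In this assay compound 2 gives > 100000 nM, which is a limit of the assay and not a number. Its value sits at the limit of > 100000 nM in this assay, at which 1 of the 3 values shown sits. The difference between the core of compound 2 and the core of compound 3 is not broken down here.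

Compound 4 `O=c1ccc(CO)n[nH]1` has not yet been measured. It arises from compound 2 by the same kind of change, (hydrogen in place of methyl on an aromatic nitrogen); the surroundings differ in that the place is meta to a hydroxymethyl group (2 heavy atoms) rather than meta to a large group. Because a 1.1-fold higher number from compound 3 to compound 1 (0.03 log units; within the scatter) stayed within the scatter, the step to compound 4 is expected to be similarly small, a step that the limit leaves unreadable from compound 2 to compound 4. Compound 4 is therefore expected to give 150000 nM, plausibly between 80000 nM and 400000 nM, and most likely the assay will again report only a limit.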

Compound 4, half-maximal inhibitory concentration: > 100000 nM
Compound 4: no number, only a limit; the forecaster's own chance of this, stated with the estimate: 75%; the middle value is on the limit's open side.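

In this assay compound 2 and compound 4 each return only a limit of the assay and not a number, so the step between them, hydrogen in place of methyl on an aromatic nitrogen, cannot be read: (the limit of > 100000 nM in this assay, at which 2 of the 4 values shown sit). The compounds shown leave open how far each of the two lies past that limit, and whether this change has any effect alongside a free hydroxymethyl group.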